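The source may hold more compounds than are shown below. What is called first, only, known or untested is meant among the compounds shown, and "the series" means these compounds.

In a functional assay on MIA PaCa-2 cells (Homo sapiens) for cytotoxicity, read by MTT assay, with a stated time of 72 h (on this read-out higher numbers stand for an effect only at larger amounts of compound and lower numbers for an effect already at smaller amounts), compound 1 `O=C1/C(=C\c2c(Cl)cccc2Cl)c2ccccc2N1c1c(Cl)cccc1Cl` gives > 100 ug/mL, which is a limit of the assay and not a number. Compound 2 `O=C1/C(=C\c2cccc(Oc3ccccc3)c2)c2ccccc2N1c1c(Cl)cccc1Cl` gives > 100 ug/mL, which is also a limit. Among the measured compounds shown here, compound 1 therefore has no exact position on the scale, and no measured step is available as a guide.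

Compound 3 `COc1ccc(/C=C2\C(=O)N(c3c(Cl)cccc3Cl)c3ccccc32)cc1` has not yet been measured. It keeps the shared core but carries 4-methoxyphenyl in place of 2,6-dichlorophenyl on a double-bonded chain carbon bound to a double-bonded ring carbon.

The expected step of an at least 1.3-fold lower number from compound 1 to compound 3 (0.12 log units; that floor lies within the scatter) is small, pointing towards an effect at smaller amounts, and it may stay within the usual scatter. This cautious expectation rests on compound 1 and compound 2 sharing (the limit of > 100 ug/mL in this assay, at which 2 of the 2 values shown sit). The reading could well stop at the limit again. For compound 3 the estimated value is 75 ug/mL, with an expected range from 25 ug/mL to 150 ug/mL.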

Compound 3, concentration for half-maximal effect: > 100 ug/mL
Compound 3 ended at the assay's limit; the forecaster's own chance of this, stated with the estimate: 55%; middle value at least 1.3-fold (0.12 log units) away from the limit.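

Compound 1 and compound 3 both stop at a limit of the assay and not at a number, and no step can be read between them. The compounds shown leave open whether 4-methoxyphenyl in place of 2,6-dichlorophenyl changes the effect at all, with every reading at the same mark: the limit of > 100 ug/mL in this assay, at which 3 of the 3 values shown sit.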